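The source may hold more compounds than are shown below. What is called first, only, known or untested is meant among the compounds shown, and "the series" means these compounds.

Measured in an ADME assay on L929 cells (Mus musculus) for cytotoxicity, read by resazurin assay, with a stated time of 96 h; a higher number here means that more compound is tolerated, a lower number that less compound is tolerated:
Compound 1 `CNC(=S)N/N=C(/COc1ccc(Br)cc1)c1ccc(F)cc1`: "not determined" (no result reported)
Compound 2 `CCc1ccc(OC/C(=N\NC(N)=S)c2ccc(Br)cc2)cc1`: < 25500 nM

Among the measured compounds shown here, compound 1 has no result, so no measured step is available as a guide. Compound 2 gives only a limit of the assay and not a number: < 25500 nM. Compound 3 `CC(C)(C)c1ccc(OC/C(=N\NC(N)=S)c2ccc(Br)cc2)cc1` keeps the core of compound 2 but has tert-butyl in place of ethyl on an aromatic carbon. The expected change in this assay, a step that the limit leaves unreadable from compound 2 to compound 3, is estimated to stay within the usual scatter, with no firm direction. For compound 3 the estimated value is 15000 nM, with an expected range of 4000 nM to 50000 nM.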

Compound 3, half-maximal cytotoxic concentration: 23800 nM
Beside the measured number, compound 3's estimate is 1.6-fold (0.20 log units) below it; low and high end bracket the measured number.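

The step from compound 2 to compound 3 cannot be read, because compound 2 gives only a limit and not a number: the limit of < 25500 nM in this assay, at which 1 of the 3 values shown sits.
From the compounds shown here alone, whether tert-butyl in place of ethyl on an aromatic carbon changes how much compound the cells tolerate stays open.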